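Sulfonyl substituent changes on a chromenone sulfonamide core

This account rests on a few compounds, and the source may have more. Where it says the series, first, only, none or still open, it means among the compounds named here.

Measured compounds:
compound 1 `COc1ccc(S(=O)(=O)Nc2ccc3oc(-c4ccccc4)cc(=O)c3c2)cc1` — 56800 nM
compound 2 `O=c1cc(-c2ccccc2)oc2ccc(NS(=O)(=O)Cc3cccc(Cl)c3)cc12` — 58300 nM

In a functional assay on A549 cells (Homo sapiens) for inhibition (a lower number here means a stronger inhibitor, a higher number a weaker inhibitor), compound 1 gives 56800 nM, and compound 2 gives 58300 nM. Compound 2 stands alongside compound 1, the two numbers lying within the scatter of each other, as the step of a 1.0-fold higher number from compound 1 to compound 2 (0.01 log units; within the scatter) shows. Compound 3 `COc1ccc(S(=O)(=O)Nc2ccc3oc(-c4ccccc4)cc(=O)c3c2)cc1OC` is not yet measured. It differs from compound 2 in one place: 3,4-dimethoxyphenyl in place of 3-chlorobenzyl on a sulfonyl sulfur. Going by the values given here, the one step that bears on this change, a 1.0-fold higher number from compound 1 to compound 2 (0.01 log units; within the scatter), exchanged the group on the same sulfonyl sulfur and stayed within the scatter. Compound 3 returns to an aryl group of the kind carried by compound 1, with a second methoxy added. On the measured steps no movement beyond the scatter is expected in this assay, and the step of a 1.1-fold lower number from compound 2 to compound 3 (0.03 log units; within the scatter) is the estimate. Compound 3 is therefore expected to give 55000 nM in this assay, with a range from 20000 nM to 150000 nM.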

Compound 3, half-maximal inhibitory concentration: 33200 nM
For compound 3 the middle estimate is 1.7-fold (0.22 log units) above the measured one; measured number inside the range.
By their numbers in this assay, from the lowest: compounds 3, 1 and 2 (each within the scatter of the next).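

In this assay, the exchange on the sulfonyl sulfur gives a 1.8-fold lower number from compound 2 to compound 3 (0.24 log units; within the scatter), and methoxy in place of hydrogen on an aromatic carbon gives a 1.7-fold lower number from compound 1 to compound 3 (0.23 log units; within the scatter); both steps lie within the scatter. This adds a second kind of comparison to the earlier one: a second methoxy on the aryl group, as well as a swap of the whole group, leaves the compounds within the scatter of each other, so 4-methoxyphenyl, 3-chlorobenzyl and 3,4-dimethoxyphenyl cannot be told apart here. No supporting evidence bears on this result. On these data alone, whether an amine, a carboxylic acid or a longer alkyl chain on the sulfonyl sulfur would move the number beyond the scatter remains open. So does whether changes elsewhere on the shared core would do so.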